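The source may report more compounds than this note shows. Statements on the series, on what has been measured and on what is new or still open speak of the compounds shown alone.

In a functional assay on A549 cells (Homo sapiens) for inhibition, read by MTT assay, with a stated time of 48 h (on this read-out lower numbers stand for stronger inhibition and higher numbers for weaker inhibition), compound 1 `Nc1n[nH]c2cccc(-c3cccc(NC(=O)Nc4nccs4)c3)c12` gives > 500000 nM, which is a limit and not a number. For the measured compounds named here, compound 2 `Nc1n[nH]c2cccc(-c3cccc(NC(=O)Nc4ccc(Cl)c(C(F)(F)F)c4)c3)c12` gives 3410 nM, the only true number so far, so it has no measured neighbour to be ranked against. Compound 3 `Nc1n[nH]c2cccc(-c3cccc(NC(=O)Nc4cccc(C(F)(F)F)c4)c3)c12` differs from compound 2 in one place, hydrogen in place of chloro on an aromatic carbon. Going by the values given here, no measured pair shows what this swap does, so only a modest shift toward weaker inhibition is expected, and with wide uncertainty. The expected change is a 1.8-fold higher number from compound 2 to compound 3 (0.25 log units; within the scatter). Compound 3 is estimated at 6000 nM, with an expected range of 2000 nM to 25000 nM.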

Compound 3, half-maximal inhibitory concentration: 1950 nM
For compound 3 the middle estimate is 3.1-fold (0.49 log units) above the measured one; measured number outside the range, below it.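

Hydrogen in place of chloro on this aromatic carbon, ortho to the trifluoromethyl group, gives a 1.7-fold lower number from compound 2 to compound 3 (0.24 log units; within the scatter), so in this assay the chloro is not needed to keep a measurable value. For the compounds shown here, the larger change, 3-(trifluoromethyl)phenyl in place of 1,3-thiazol-2-yl on the amide-type nitrogen, gives an at least 250-fold lower number from compound 1 to compound 3 (2.40 log units; beyond the scatter), the first step here that lies beyond the scatter. The value of compound 1 is a limit, so this step is a minimum: the limit of > 500000 nM in this assay, at which 1 of the 3 values shown sits.

From the compounds shown here alone, what a methoxy group or an amine would do on this aromatic carbon stays open. So does what the phenyl ring would give without its trifluoromethyl group.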